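The source may hold more compounds than are shown below. What is called first, only, known or untested is meant among the compounds shown, and "the series" means these compounds.

In a functional assay on CCRF-CEM cells (Homo sapiens) for antiproliferative activity, read by MTT assay, with a stated time of 24 h, tested at 100 uM (a higher number here means a weaker effect of the compound at the concentration tested, a lower number a stronger effect), compound 2 `OC(CCn1nc2c(Br)c(Br)c(Br)c(Br)c2n1)c1cccc(Cl)c1` gives 0%. Within the data shown here, its only neighbour in the set, compound 1 `OCC(O)Cn1nc2c(Br)c(Br)c(Br)c(Br)c2n1`, gives 8% in this assay, and the gap between the two lies within the scatter of this kind of measurement, so compound 2 holds the smaller of the two numbers without being separable from compound 1. Compound 3 `CC(O)CCn1nc2c(Br)c(Br)c(Br)c(Br)c2n1` has not been measured. It differs from compound 2 by methyl in place of 3-chlorophenyl on a saturated chain carbon bound to an oxygen on a saturated carbon and a saturated chain carbon. Among the measured compounds shown here, no step between measured compounds is available that would show what such a change does to this assay, so the expectation rests on the two numbers alone. The step of a number 8 percentage points higher from compound 2 to compound 3 (within the scatter) is expected to be small and in no direction beyond the scatter. Compound 3 is therefore estimated at 8% in this assay, with a range from 0% to 30%.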

Compound 3, a percentage reported as activity, at one concentration (the size of the read-out at that concentration, not a potency): 3%
The estimate for compound 3 lay 5 percentage points above the measured number; the measured number falls inside the stated range.
By their numbers in this assay, from the lowest: compounds 2, 3 and 1 (each within the scatter of the next).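

In this assay, methyl in place of 3-chlorophenyl on a saturated chain carbon bound to an oxygen on a saturated carbon and a saturated chain carbon gives a number 3 percentage points higher from compound 2 to compound 3 (within the scatter), so removing the six-membered aromatic ring at this position does not separate the two compounds. Likewise, 2-hydroxypropyl in place of 1,2-dihydroxyethyl on a saturated chain carbon bound to an aromatic nitrogen gives a number 5 percentage points lower from compound 1 to compound 3 (within the scatter), so neither change moves the read-out at the concentration tested beyond the scatter. Nothing available accounts for this result.

On these data alone, whether an amine or a carboxylic acid in place of methyl at this position would shift the number beyond the scatter remains open. A read-out at one concentration is not a potency, so any difference among these compounds at lower concentrations also remains unknown.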